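A few compounds are considered here, and "the series" means these few. Any claim that something is new, unique, unknown or untested is made for them only; others in the source may bear on it.

Measured in a functional assay on A549/CDDP cells (Homo sapiens) for antiproliferative activity, read by MTT assay, with a stated time of 72 h; on this read-out lower numbers stand for stronger inhibition and higher numbers for weaker inhibition:
- compound 1 `Cc1nc(C)c(/C=C/C(=O)/C=C/c2cccc(O)c2)nc1C`: 3700 nM
- compound 2 `COc1ccc(/C=C/C(=O)/C=C/c2nc(C)c(C)nc2C)c(OC)c1`: 2850 nM
- compound 3 `COc1cc(/C=C/C(=O)/C=C/c2nc(C)c(C)nc2C)cc(OC)c1OC`: 1000 nM

Among these three, compound 1 lies at the upper end of the numbers. Compound 2 falls within the scatter of it, while compound 3 has a lower number, beyond the scatter.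

The next compound to be tested is compound 4 `Cc1nc(C)c(/C=C/C(=O)/C=C/c2ccccc2)nc1C`. It departs from compound 1 in one place: hydrogen in place of hydroxy on an aromatic carbon. This puts hydrogen in place of hydroxy on an aromatic carbon, taking 3-hydroxyphenyl to phenyl.

Among the measured compounds shown here, no measured pair isolates this change, so the expectation rests only on the spread of the three values. No step beyond the scatter is expected in this assay, and no clear direction can be drawn from the data, though a slightly lower number is assumed. The expected 1.2-fold lower number from compound 1 to compound 4 (0.09 log units; within the scatter) therefore stays small. For compound 4 the estimated value is 3000 nM, with an expected range from 1200 nM to 7500 nM.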

Compound 4, half-maximal inhibitory concentration: 11900 nM
For compound 4 the middle estimate is 4.0-fold (0.60 log units) below the measured one; measured number outside the range, above it.
By their numbers in this assay, from the lowest: compound 3; then compounds 2 and 1 (each within the scatter of the next); then compound 4.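

In this assay, taking 3-hydroxyphenyl to phenyl gives a 3.2-fold higher number from compound 1 to compound 4 (0.51 log units; beyond the scatter) and so lies beyond the scatter, which shows that this position on the aromatic ring is not indifferent to the change. Losing the hydroxy group weakens the antiproliferative read-out, and this pair supplies the first direct reading of a single change among the compounds shown. Nothing measured here accounts for this step.

The compounds shown leave open whether this difference is specific to the hydroxy group or whether another group on the same aromatic carbon, such as an amine, a carboxylic acid or a fluorine atom, would also give a lower number than compound 4 does. They also leave open whether a hydroxy group placed elsewhere on this ring would produce a step of similar size.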